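Adding Benzyloxy to Compound 2: A Cytotoxicity Estimate

The source may hold more compounds than are shown below. What is called first, only, known or untested is meant among the compounds shown, and "the series" means these compounds.

Compound 1 `NS(=O)(=O)c1ccc(N2N=C(c3ccc(OCc4ccccc4)cc3)CC2c2ccccc2)cc1`: 80000 nM
Compound 2 `Cc1cccc(C2CC(c3ccccc3)=NN2c2ccc(S(N)(=O)=O)cc2)c1`: 25000 nM

In an ADME assay on BHK-21 cells (Mesocricetus auratus) for cytotoxicity, read by MTT assay, with a stated time of 72 h (a higher number here means that more compound is tolerated, a lower number that less compound is tolerated), compound 2 gives 25000 nM, the lower of the two numbers and beyond the usual scatter from compound 1. Compound 3 `Cc1cccc(C2CC(c3ccc(OCc4ccccc4)cc3)=NN2c2ccc(S(N)(=O)=O)cc2)c1` follows from compound 2 by one change, benzyloxy in place of hydrogen on an aromatic carbon. Compound 1 also carries benzyloxy and gives 80000 nM, so a moderate rise in this assay is expected, with more compound tolerated. The expected step is a 2.2-fold higher number from compound 2 to compound 3 (0.34 log units; beyond the scatter). The estimate for compound 3 is 55000 nM, with an expected range from 22000 nM to 130000 nM.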

Compound 3, half-maximal cytotoxic concentration: 8000 nM
The estimate for compound 3 lay 6.9-fold (0.84 log units) above the measured number; the whole stated range lies above it.
By their numbers in this assay, from the lowest: compound 3; then compound 2; then compound 1.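

In this assay, benzyloxy in place of hydrogen on an aromatic carbon gives a 3.1-fold lower number from compound 2 to compound 3 (0.49 log units; beyond the scatter) and so lowers the tolerated amount when the methyl is present. Methyl in place of hydrogen on an aromatic carbon gives a 10-fold lower number from compound 1 to compound 3 (1.00 log units; beyond the scatter) once benzyloxy is there, so the high number of compound 1 does not survive this small addition. No measurement here explains either drop. Still open, going by these compounds, is whether methoxy or an amine at this same place would lower the number as well.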